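Dienamide Side Chains on a Shared Dimethoxyphenyl Core

A few compounds are considered here, and "the series" means these few. Any claim that something is new, unique, unknown or untested is made for them only; others in the source may bear on it.

Measured so far:
compound 1 `COc1ccc(C[C@@H](O)/C=C/C=C/C(=O)N2CCN(c3ccccn3)CC2)cc1OC` gives 11100 nM
compound 2 `CCNC(=O)/C=C/C=C/[C@H](O)Cc1ccc(OC)c(OC)c1` gives 9430 nM

Both compounds share the same hydroxy-dienamide core and were tested in a functional assay on IMR-32 cells (Homo sapiens) for antiproliferative activity, read by sulforhodamine B assay, with a stated time of 48 h; on this read-out higher numbers stand for weaker inhibition and lower numbers for stronger inhibition. Compound 1 and compound 2 give numbers that sit within the usual scatter of each other, so the two cannot be told apart on this read-out; compound 2 is simply one of two closely matched values. Going by the values given here, no single-point step between them is available, since they differ at more than one place.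

Compound 3 `COc1ccc(C[C@@H](O)/C=C/C=C/C(=O)N2CCN(C)CC2)cc1OC` has not yet been measured. It differs from compound 2 by 4-methylpiperazin-1-yl in place of ethylamino on a carbonyl carbon. Compound 1, which also carries a piperazine amide, is within the scatter of compound 2 9430 nM, so no step beyond the scatter is expected for a 1.1-fold higher number from compound 2 to compound 3 (0.03 log units; within the scatter). Compound 3 is therefore estimated at 10000 nM, with a range from 4000 nM to 25000 nM.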

Compound 3, half-maximal inhibitory concentration: 18900 nM
Beside the measured number, compound 3's estimate is 1.9-fold (0.28 log units) below it, within the range that was stated.
By their numbers in this assay, from the lowest: compounds 2, 1 and 3 (each within the scatter of the next).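

Going by these compounds alone, compound 3 gives the first single-place comparisons in this assay: 4-methylpiperazin-1-yl in place of ethylamino on a carbonyl carbon gives a 2.0-fold higher number from compound 2 to compound 3 (0.30 log units; within the scatter), and methyl in place of pyridin-2-yl on an amine nitrogen in a ring gives a 1.7-fold higher number from compound 1 to compound 3 (0.23 log units; within the scatter). Within the data shown here, both steps lie within the scatter, so neither change separates its pair on this read-out, even though the first swaps an open group with a hydrogen-bond donor for a six-membered non-aromatic ring without one. No available evidence bears on these results.

The compounds shown leave open whether a longer alkyl chain or a hydroxyethyl group in place of ethylamino would give a step beyond the scatter. Going by these compounds, it also remains open whether a benzyl group in place of methyl on the ring nitrogen would do so.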